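The source may report more compounds than this note shows. Statements on the series, on what has been measured and on what is new or still open speak of the compounds shown alone.

In an ADME assay on the whole organism (Mus musculus, strain ICR(CD-1)) for metabolic stability, read by mass spectrometry, at a dose of 10 mg/kg by the oral route (on this read-out lower numbers stand for a shorter-lived compound and higher numbers for a longer-lived compound), three compounds sharing one core have been measured so far. Compound 1 `Cc1ccc(C(=O)Nc2cccc(C(F)(F)F)c2)cc1-c1ccc2c(-c3cnn(C)c3)n[nH]c2c1` gives 2.75 h, compound 2 `Cc1ccc(C(=O)Nc2cccc(C(F)(F)F)c2)cc1-c1ccc2c(-c3cnn(C4CC4)c3)n[nH]c2c1` gives 3.05 h, and compound 3 `Cc1ccc(C(=O)Nc2cccc(C(F)(F)F)c2)cc1-c1ccc2c(-c3cnn(CC(C)O)c3)n[nH]c2c1` gives 0.75 h. Compound 3 is thus the lowest of the three, and its gap to each of the others lies beyond the scatter.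

Compound 4 `Cc1ccc(C(=O)Nc2cccc(C(F)(F)F)c2)cc1-c1ccc2c(-c3cnn(C4CCN(C)CC4)c3)n[nH]c2c1` has not yet been measured. It carries 1-methylpiperidin-4-yl in place of 2-hydroxypropyl on an aromatic nitrogen. Among the measured compounds shown here, no measured compound carries 1-methylpiperidin-4-yl, so the evidence is indirect.

For the measured compounds named here, three measured steps bear on this change, all made at the same aromatic nitrogen. Cyclopropyl in place of methyl gave a 1.1-fold higher number from compound 1 to compound 2 (0.04 log units; within the scatter). The two steps that introduced the 2-hydroxypropyl group gave a 3.7-fold lower number from compound 1 to compound 3 (0.56 log units; beyond the scatter) and a 4.1-fold lower number from compound 2 to compound 3 (0.61 log units; beyond the scatter), both modest. Removing that group in compound 4 is therefore expected to reverse a step of similar size, on the reasoning that compound 4 may fall closer to compound 2 at 3.05 h than to compound 3. The expected change is a 3.3-fold higher number from compound 3 to compound 4 (0.52 log units; beyond the scatter), a modest rise. Compound 4 is estimated at 2.5 h, with an expected range of 1 h to 6 h.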

Compound 4, half-life: 2.75 h
Estimate against measurement, compound 4: 1.1-fold (0.04 log units) below; measured number inside the range.
By their numbers in this assay, from the lowest: compound 3; then compounds 1, 4 and 2 (each within the scatter of the next).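

In this assay, the result shows that a large group on this aromatic nitrogen need not shorten the half-life: 1-methylpiperidin-4-yl, with its six-membered non-aromatic ring, brings a clear rise over the smaller, ring-free 2-hydroxypropyl (a 3.7-fold higher number from compound 3 to compound 4 (0.56 log units; beyond the scatter)). The steps to the other two compounds, a 1.1-fold lower number from compound 2 to compound 4 (0.04 log units; within the scatter) and no change at the digits printed from compound 1 to compound 4 (within the scatter), place methyl, cyclopropyl and 1-methylpiperidin-4-yl together within the scatter, so among these four compounds, only compound 3 stands apart and the half-life does not follow the size of the group. Nothing at hand gives a cause for this separation.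

On these data alone, what remains open is whether the low number of compound 3 belongs to the hydroxyl of its chain or to the chain itself, a question that a plain propyl chain or a 2-methoxypropyl group at the same nitrogen could address. As far as these compounds go, it is also open whether the ring nitrogen or its methyl counts at all, which piperidin-4-yl without the methyl, or tetrahydropyran-4-yl with an oxygen in the ring, could test.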